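Working notes: three measured compounds and one proposed analogue

The compounds below may be only part of what the source reports. "The series", "measured", "known", "first", "only" and "open" are said of these compounds alone.

The series holds three measured compounds and one not yet measured. Compound 1 is `Oc1cccc2cc(-c3ccc(F)cc3)ccc12`. In an assay for binding affinity to 17-beta-hydroxysteroid dehydrogenase type 1 (Homo sapiens), with a stated time of 20 min, tested at 1 uM (a lower number here means less inhibition, a higher number more inhibition at the concentration tested (going by the name of the read-out)), compound 1 gives < 10%, which is a limit of the assay and not a number. Compound 2 is `Oc1cccc2cc(-c3ccncc3)ccc12`; in this assay compound 2 gives < 10%, again a limit. Compound 3 is `Oc1cccc2cc(-c3ccoc3)ccc12`; in this assay compound 3 gives < 10%, also a limit. Compound 1 therefore stands with the other two at the limit: the limit of < 10% in this assay, at which 3 of the 3 values shown sit. Nothing in these readings separates the three.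

Compound 4 is `CS(=O)(=O)Nc1ccc(-c2ccc3c(O)cccc3c2)cc1`. Against compound 1 the change is methanesulfonamido in place of fluoro on an aromatic carbon. Within the data shown here, no step between measured compounds exists in this set, so the size of such a change cannot be read from any measured pair. The step from compound 1 to compound 4 is expected to be a number at least 2 percentage points higher from compound 1 to compound 4 (that floor lies within the scatter), small and within the scatter. Compound 4 is estimated at 12%, with a range from 0% to 35%, and a reading that is again only a limit is expected to be the more likely outcome.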

Compound 4, a percentage reported as inhibition, at one concentration (the size of the read-out at that concentration, not a potency): 52%
The estimate for compound 4 lay 40 percentage points below the measured number; measured number outside the range, above it.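

In this assay, the aromatic carbon para to a large group proves able to carry a change that moves the reading clear of the limit: methanesulfonamido in place of fluoro gives a number at least 42 percentage points higher from compound 1 to compound 4 (beyond the scatter). Compound 1 gives < 10%, which is a limit of the assay and not a number, so the printed step is a floor and its full size cannot be read. Compound 4 is the only compound shown that stands off that limit: the limit of < 10% in this assay, at which 3 of the 4 values shown sit.

On these data alone, whether an amine, a carboxylic acid or a longer chain on the sulfonyl group at this same position would read like compound 4 stays open. Also open, as far as these compounds go, is how compound 4 behaves at other concentrations, as a single percentage is not a potency.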